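Methyl in Place of Chloro: From Compound 2 to Compound 4

The compounds below may be only part of what the source reports. "The series", "measured", "known", "first", "only" and "open" are said of these compounds alone.

Of the compounds shown here, three built on the shared core have so far been tested in a functional assay on the whole organism (strain Albino) for inhibition, with Rattus norvegicus as the target, with stated times of 1 h and 3 h, at a dose of 20 mg/kg by the oral route; on this read-out lower numbers stand for less inhibition and higher numbers for more inhibition at the one dose given (going by the name of the read-out). Compound 1 `O=C(O)CCC1=C(c2ccc(Cl)cc2)NC(=S)NC1c1ccccc1O` gives 1.22%. Compound 2 `O=C(O)CCC1=C(c2ccc(Cl)cc2)NC(=S)NC1c1ccco1` gives 5.52%, and compound 3 `O=C(O)CCC1=C(c2ccc(Cl)cc2)NC(=S)NC1c1ccccn1` gives 5.52%. Every measured step among them varies the group on a saturated ring carbon: a number 4.3 percentage points higher from compound 1 to compound 2 (within the scatter), a number 4.3 percentage points higher from compound 1 to compound 3 (within the scatter) and no change at the digits printed from compound 2 to compound 3 (within the scatter), each within the scatter. Among the compounds with values here, compound 2 therefore stands level with compound 3 and within the scatter of compound 1, with no compound set apart from the others.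

Compound 4 `Cc1ccc(C2=C(CCC(=O)O)C(c3ccco3)NC(=S)N2)cc1` differs from compound 2 in a different place: methyl in place of chloro on an aromatic carbon. Within the data shown here, no measured step touches this aromatic carbon, so none bears directly on the change; what the three known steps show, all within the scatter, is a read-out that has stayed flat across compounds 1, 2 and 3. The expected step is accordingly a number 0 percentage points lower from compound 2 to compound 4 (within the scatter), nothing beyond the scatter. Compound 4 is estimated at 5.5%, within 0% to 16%.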

Compound 4, a percentage reported as inhibition, in the whole organism at one dose (the size of the read-out at that dose, not a potency): 10.4%
Beside the measured number, compound 4's estimate is 4.9 percentage points below it; low and high end bracket the measured number.
By their numbers in this assay, from the lowest: compounds 1, 2, 3 and 4 (each within the scatter of the next).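

The exchange of 4-chlorophenyl for 4-methylphenyl is the first step shown at this aromatic carbon, and in this assay it reads as a number 4.9 percentage points higher from compound 2 to compound 4 (within the scatter). With furan-2-yl held on the saturated ring carbon, methyl and chloro therefore cannot be told apart on this read-out, so this aromatic carbon joins the saturated ring carbon as a place where no step beyond the scatter is shown. No measurement shown here offers an explanation for this step.

Going by these compounds, it remains open whether the same exchange would read alike with 2-hydroxyphenyl or pyridin-2-yl on the saturated ring carbon. On these data alone, it is also open whether a different group on this aromatic carbon, such as methoxy, trifluoromethyl or an amine, would move the read-out beyond the scatter.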